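Chloro in place of hydroxy: an untested step

The source may hold more compounds than are shown below. What is called first, only, known or untested is meant among the compounds shown, and "the series" means these compounds.

In a functional assay on DU-145 cells (Homo sapiens) for inhibition, read by trypan blue exclusion, with a stated time of 96 h (on this read-out lower numbers stand for stronger inhibition of growth and higher numbers for weaker inhibition of growth), compound 1 `O=C(O)c1ccc(C(=O)/C(=C\c2ccc(O)c([N+](=O)[O-])c2)SCc2ccc(Br)cc2)cc1` gives 50000 nM, the higher of the two exact numbers in this small set. Compound 2 `COc1ccc(C(=O)/C(=C\c2ccc(O)c([N+](=O)[O-])c2)SCc2ccc(Br)cc2)cc1` gives 10000 nM, the nearest value. For compound 3 `O=C(/C(=C\c1ccc(O)c([N+](=O)[O-])c1)SCc1ccc(Br)cc1)c1ccc(O)cc1O` the result is only a limit, > 100000 nM.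

Compound 4 `O=C(O)c1ccc(C(=O)/C(=C\c2ccc(Cl)c([N+](=O)[O-])c2)SCc2ccc(Br)cc2)cc1` has not yet been measured in this assay. It differs from compound 1 in one place: chloro in place of hydroxy on an aromatic carbon. This is chloro in place of hydroxy on an aromatic carbon, ortho to a nitro group, so that 4-hydroxy-3-nitrophenyl becomes 4-chloro-3-nitrophenyl.

Going by the values given here, no measured step touches that place. All three lie at the group on the carbonyl carbon. Methoxy in place of carboxy gave a 5.0-fold lower number from compound 1 to compound 2 (0.70 log units; beyond the scatter). Replacing 4-methoxyphenyl with 2,4-dihydroxyphenyl gave an at least 10-fold higher number from compound 2 to compound 3 (1.00 log units; beyond the scatter). Replacing 4-carboxyphenyl with 2,4-dihydroxyphenyl gave an at least 2.0-fold higher number from compound 1 to compound 3 (0.30 log units; that floor lies within the scatter). These steps show that numbers in this set can move, but they give no direction for the new exchange. The central expectation is therefore no step beyond the scatter, although a modest move either way remains possible. The expected step is a 1.7-fold lower number from compound 1 to compound 4 (0.22 log units; within the scatter). The estimate for compound 4 is 30000 nM, with an expected range from 8000 nM to 100000 nM.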

Compound 4, concentration for 50% growth inhibition: 500 nM
Beside the measured number, compound 4's estimate is 60-fold (1.78 log units) above it, and the stated range ends above it.
By their numbers in this assay, from the lowest: compound 4; then compound 2; then compound 1. At a limit, above all of these: compound 3.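

In this assay, going by these compounds alone, chloro in place of hydroxy on the aromatic carbon ortho to a nitro group gave a 100-fold lower number from compound 1 to compound 4 (2.00 log units; beyond the scatter), at a place that none of the earlier steps touched. The earlier compounds shown here differed only in the group on the carbonyl carbon, so they could not show that the 4-hydroxy-3-nitrophenyl part of the core also governs the number; this single exchange shows that it does, and that a compound keeping the 4-carboxyphenyl group need not stay high on this read-out. Why the exchange has this effect cannot be told, as nothing given here bears on its cause.

Whether the step belongs to chloro itself or to the loss of hydroxy stays open, since the compounds shown offer no bromo, fluoro, methoxy or amine at this aromatic carbon. They also leave open whether the same exchange would carry over to a compound with 4-methoxyphenyl or 2,4-dihydroxyphenyl on the carbonyl carbon, as in compound 2 and compound 3, the latter known here only as a limit.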